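This account rests on a few compounds, and the source may have more. Where it says the series, first, only, none or still open, it means among the compounds named here.

Compound 1 `COc1ccc(C(=O)N[C@H]2CCC[C@H](NC(=O)c3cccc(Cl)c3)C2)cc1` and compound 2 `O=C(Cc1ccccn1)N[C@H]1CCC[C@H](NC(=O)c2cccc(Cl)c2)C1` share one core that carries two amide groups and differ only in the group attached to one carbonyl carbon. In a functional assay on HEK293 cells for antagonist activity at metabotropic glutamate receptor 5 (Homo sapiens), read by FLIPR and calcium flux (a higher number here means a weaker inhibitor, a lower number a stronger inhibitor), compound 1 gives 266 nM. For compound 2 the result in this assay is only a limit of the assay, > 10000 nM, so compound 2 stands at the weak end of what has been measured. The step of an at least 37-fold higher number from compound 1 to compound 2 (1.57 log units; beyond the scatter) shows that placing (pyridin-2-yl)methyl in place of 4-methoxyphenyl on the carbonyl carbon loses inhibition, and its true size is hidden by the limit of > 10000 nM in this assay, at which 1 of the 2 values shown sits. Compound 3 `O=C(N[C@H]1CCC[C@H](NC(=O)c2cccc(Cl)c2)C1)c1ccncc1` differs from compound 2 by pyridin-4-yl in place of (pyridin-2-yl)methyl on a carbonyl carbon, which returns an aromatic ring directly onto the carbonyl carbon, as in compound 1. Within the data shown here, only that single step bears on this change, and it was large. Compound 3 undoes part of that exchange, and a return toward lower numbers in this assay is expected, though its ring is not the 4-methoxyphenyl of compound 1. Compound 3 is therefore estimated at 1200 nM, between 250 nM and 6000 nM. The step of an at least 8.3-fold lower number from compound 2 to compound 3 (0.92 log units; beyond the scatter) is expected to run toward stronger inhibition.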

Compound 3, half-maximal inhibitory concentration: 300 nM
The estimate for compound 3 lay 4.0-fold (0.60 log units) above the measured number, within the range that was stated.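

In this assay the step of an at least 33-fold lower number from compound 2 to compound 3 (1.52 log units; beyond the scatter) shows that the loss seen with (pyridin-2-yl)methyl does not extend to every pyridine-bearing group on this carbonyl carbon, since the leaving and entering groups each hold one six-membered aromatic ring with 1 hetero atom. The true size of that step cannot be given because compound 2 stands at a limit of the assay: the limit of > 10000 nM in this assay, at which 1 of the 3 values shown sits. The step of a 1.1-fold higher number from compound 1 to compound 3 (0.05 log units; within the scatter) adds that pyridin-4-yl and 4-methoxyphenyl cannot be told apart at this position in this assay, so a methoxy group is not required for this level of inhibition.

The step from (pyridin-2-yl)methyl to pyridin-4-yl changes both the carbon link to the ring and the attachment point on the pyridine, and the compounds shown do not separate these two changes; pyridin-2-yl set directly on the carbonyl carbon and (pyridin-4-yl)methyl remain open. Also open, going by these compounds, is how an unsubstituted phenyl ring, or a pyridin-4-yl ring carrying an amine or a methoxy group, would read in this assay at this position.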